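The source may report more compounds than this note shows. Statements on the series, on what has been measured and on what is new or still open speak of the compounds shown alone.

Measured so far:
Compound 1 `COCc1nnc(N2CC3CN(c4ccc(F)cc4Cl)C3C2)n1-c1ccc(OC)nc1` gives 121 nM in a functional assay on HEK293 cells for antagonist activity at Oxytocin receptor (Homo sapiens), read by calcium flux, with a stated time of 10 min, in the presence of a further agent that is not named here; on this read-out lower numbers stand for stronger inhibition and higher numbers for weaker inhibition.
Compound 2 `COc1ccc(-n2c(COCCF)nnc2N2C[C@@H]3C[C@]3(c3ccc(F)cc3Cl)C2)cn1` gives 44 nM in this assay.

Compound 2 holds the lowest of the two numbers in this assay; compound 1 sits higher, a gap beyond the scatter. Compound 3 `COc1ccc(-n2c(C3CC3)nnc2N2C[C@@H]3C[C@]3(c3ccc(F)cc3Cl)C2)cn1` differs from compound 2 by cyclopropyl in place of (2-fluoroethoxy)methyl on an aromatic carbon. Within the data shown here, no measured pair shows this change, so its step size is unknown; a small step is expected, likely within the scatter, if anything towards a higher number. Compound 3 is expected at 70 nM, with a range of 25 nM to 200 nM. That estimate corresponds to an expected step of a 1.6-fold higher number from compound 2 to compound 3 (0.20 log units; within the scatter).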

Compound 3, half-maximal inhibitory concentration: 433 nM
For compound 3 the middle estimate is 6.2-fold (0.79 log units) below the measured one; the measured number lies above the stated range.
By their numbers in this assay, from the lowest: compound 2; then compound 1; then compound 3.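

In this assay, the group on the aromatic carbon between two ring nitrogen atoms clearly matters: cyclopropyl in place of (2-fluoroethoxy)methyl gives a 9.8-fold higher number from compound 2 to compound 3 (0.99 log units; beyond the scatter), a step beyond the scatter. On this core, the change to a smaller group that carries a ring and no hydrogen-bond acceptor goes with weaker inhibition. Nothing measured here gives a reason for this step.

This single pair cannot separate the contributions of the chain's oxygen, its fluorine and its length. A plain propyl chain or an aminomethyl group at this position remains an open comparison.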